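The compounds below may be only part of what the source reports. "The series", "measured", "known", "first", "only" and "open" are said of these compounds alone.

So far, two compounds that share a core and differ only in the group on the sulfonyl sulfur have been measured. In an ADME assay on microsomes (Mus musculus) for metabolic stability (on this read-out higher numbers stand for fast clearance and lower numbers for slow clearance), compound 1 (`Cc1cc(C(F)(F)F)c2cccc(OCc3c(Cl)ccc(S(=O)(=O)N4CCC[C@H]4C(N)=O)c3Cl)c2n1`) gives 12600 mL/min/kg. Compound 2 (`Cc1cc(C(F)(F)F)c2cccc(OCc3c(Cl)ccc(S(=O)(=O)N4C[C@@H](C)O[C@@H](C)C4)c3Cl)c2n1`) gives 933 mL/min/kg, the lower of the two numbers. The next candidate is compound 3 (`Cc1cc(C(F)(F)F)c2cccc(OCc3c(Cl)ccc(S(=O)(=O)N4CCC(C#N)CC4)c3Cl)c2n1`), which keeps the core and has 4-cyanopiperidin-1-yl in place of 2,6-dimethylmorpholin-4-yl on a sulfonyl sulfur. Within the data shown here, only one measured step bears on this change, and it sits at the same place. It is a 14-fold lower number from compound 1 to compound 2 (1.13 log units; beyond the scatter), a large step beyond the scatter. That step shows that swapping the group here can move the number in this assay a long way. However, it involved a different pair of groups, so it gives no firm direction for the new swap. With no closer comparison available, only a small rise, within the scatter, is expected. The expected change is a 1.5-fold higher number from compound 2 to compound 3 (0.18 log units; within the scatter). For compound 3 the estimated clearance is 1400 mL/min/kg, with an expected range from 450 mL/min/kg to 4500 mL/min/kg.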

Compound 3, clearance: 1720 mL/min/kg
The estimate for compound 3 lay 1.2-fold (0.09 log units) below the measured number, and the stated range covers the measured number.
By their numbers in this assay, from the lowest: compounds 2 and 3 (each within the scatter of the next); then compound 1.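

In this assay the change from 2,6-dimethylmorpholin-4-yl to 4-cyanopiperidin-1-yl gives a 1.8-fold higher number from compound 2 to compound 3 (0.27 log units; within the scatter), so at this place on the sulfonyl sulfur these two rings cannot be told apart, even though one carries a ring oxygen and two defined stereocentres and the other a nitrile and no defined stereocentre. The second new step, a 7.3-fold lower number from compound 1 to compound 3 (0.86 log units; beyond the scatter), shows that the earlier large fall was not tied to 2,6-dimethylmorpholin-4-yl alone, since a second replacement for 2-carbamoylpyrrolidin-1-yl also ends beyond the scatter from compound 1, although this step is modest rather than large. No measurement at hand speaks to what lies behind these numbers.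

The compounds shown leave open whether the high number of compound 1 belongs to the carbamoyl group or to the pyrrolidine ring that carries it, a question that a plain pyrrolidin-1-yl group on the same sulfur would help to settle. They also leave open how a plain piperidin-1-yl group, or a piperidine ring carrying a carboxylic acid or an amine in place of the nitrile, would read in this assay.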